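This account rests on a few compounds, and the source may have more. Where it says the series, first, only, none or still open, it means among the compounds named here.

For the measured compounds named here, in an ADME assay on microsomes from liver (Homo sapiens) for metabolic stability, with a stated time of 60 min, tested at 1 uM (a lower number here means that less of the compound is left, a higher number that more of the compound is left), compound 3 `COc1cnc2c(-c3ccnc(OC)c3)cnn2c1` gives 2%, the lowest of the three numbers so far. Compound 2 `COc1cc(-c2cnn3cc(OC)c([C@@H]4COC(C)(C)C4)nc23)ccn1` gives 13% and compound 1 `COc1cc(-c2cnn3cc(OC)c(C4CCOC4)nc23)ccn1` gives 29%; both lie above compound 3 by more than the scatter.

The next compound is compound 4 `COc1cc(-c2cnn3cc(OC)c([C@H]4COC(C)(C)C4)nc23)ccn1`, and the change is a group of 7 heavy atoms (6 carbon, 1 oxygen; one five-membered non-aromatic ring with 1 hetero atom) in place of a hydrogen atom, on an aromatic carbon. The incoming group sits on an aromatic carbon, next to the ring nitrogen and ortho to a methoxy group.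

Going by the values given here, two measured steps bear on this change, both read in reverse: a number 11 percentage points lower from compound 2 to compound 3 (beyond the scatter) and a number 27 percentage points lower from compound 1 to compound 3 (beyond the scatter). Both are modest. The first is the closer guide, as compound 2 carries the same group as compound 4 apart from the defined stereocentre. A modest rise from compound 3 is therefore expected in this assay, since compound 2 stands at 13%. The effect of the stereocentre is not known from these data, so the range is kept wide.

The expected step is a number 13 percentage points higher from compound 3 to compound 4 (beyond the scatter). Compound 4 is estimated at 15%, with an expected range of 5% to 30%.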

Compound 4, percent of the compound remaining: 21%
Estimate against measurement, compound 4: 6 percentage points below; measured number inside the range.
By their numbers in this assay, from the lowest: compound 3; then compounds 2, 4 and 1 (each within the scatter of the next, the first and the last beyond it).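

In this assay, the hydrogen-to-ring change at this aromatic carbon, next to the ring nitrogen, now also holds for the second configuration, with a number 19 percentage points higher from compound 3 to compound 4 (beyond the scatter). Configuration at the saturated ring carbon is tested here in isolation, and the step, a number 8 percentage points higher from compound 2 to compound 4 (within the scatter), gives no separation, the comparison resting on this: the fact that compounds 2 and 4 differ only in the configuration as drawn. Oxolan-3-yl and the group of 7 heavy atoms are likewise not separated in this configuration, with a number 8 percentage points lower from compound 1 to compound 4 (within the scatter), although the other configuration gave a number 16 percentage points lower from compound 1 to compound 2 (beyond the scatter).

Going by these compounds, whether an amine or an open-chain ether on this carbon would give a different percentage of compound remaining stays open. Also open, on these data alone, is whether either configuration would separate from the other on a core carrying something other than the two methoxy groups.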